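A few compounds are considered here, and "the series" means these few. Any claim that something is new, unique, unknown or untested is made for them only; others in the source may bear on it.

In a functional assay on L02 cells (Homo sapiens) for inhibition, read by Griess assay, with stated times of 1 h and 24 h (a lower number here means a stronger inhibitor, a higher number a weaker inhibitor), compound 2 `C(=C/c1ccco1)\c1nc(NC2CC2)c2sccc2n1` gives > 1000000 nM, which is a limit of the assay and not a number. Compound 3 `CN1CCN(c2nc(/C=C/c3ccco3)nc3ccsc23)CC1` gives > 1000000 nM, also a limit. Compound 1 `Fc1ccc(CNc2nc(/C=C/c3ccccc3)nc3ccsc23)cc1`, which also carries a 4-fluorobenzyl group, gives > 1000000 nM, again a limit. Compound 2 therefore has no measured number to be ranked against, and the evidence so far is the limit of > 1000000 nM in this assay, at which 3 of the 3 values shown sit.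

Compound 4 `Fc1ccc(CNc2nc(/C=C/c3ccco3)nc3ccsc23)cc1` is reached from compound 2 by putting 4-fluorobenzyl in place of cyclopropyl on a nitrogen on an aromatic ring. Among the measured compounds shown here, the one measured step is a step that the two limits leave unreadable from compound 2 to compound 3, so it offers no size to carry over to this change. Resting on these limits alone, the expected size of the change is a number no higher from compound 2 to compound 4 (the limit leaves the size open), with no direction expected beyond the usual scatter. Compound 4 is therefore estimated at 1000000 nM, with an expected range of 300000 nM to 3000000 nM.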

Compound 4, half-maximal inhibitory concentration: > 1000000 nM
Compound 4: no number, only a limit (the forecaster's own chance of this, stated with the estimate: 75%); the middle value lies on the limit itself.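

Compound 4, compound 1 and compound 2 all stand at a limit of the assay and not at a number, so neither step into compound 4 can be read. The compounds shown leave open whether any of these changes alters inhibition in this assay, and the evidence stops at one shared limit: the limit of > 1000000 nM in this assay, at which 4 of the 4 values shown sit.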